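Spirocyclic amine variation in a cytotoxicity series

This account rests on a few compounds, and the source may have more. Where it says the series, first, only, none or still open, it means among the compounds named here.

Measured so far:
compound 1 `COc1ccc2[nH]c(C(=O)N3CC(=O)N(Cc4ccccc4)[C@@H](CN4CCC5(CC4)CC5)C3)cc2c1`, 17100 nM
compound 2 `Cc1ccc2[nH]c(C(=O)N3CC(=O)N(Cc4ccccc4)[C@@H](CN4CCC5(CCC5)CC4)C3)cc2c1`, 7800 nM
compound 3 `COc1cccc(CN2C(=O)CN(C(=O)c3cc4cc(OC)ccc4[nH]3)C[C@@H]2CC2CCCCC2)c1`, a limit, > 10000 nM

In an ADME assay on Vero cells (Chlorocebus sabaeus) for cytotoxicity, with a stated time of 7 days (a higher number here means that more compound is tolerated, a lower number that less compound is tolerated), compound 1 gives 17100 nM, the highest of the two numbers available. Compound 2 gives 7800 nM in this assay, a lower number than compound 1 and beyond the scatter. For compound 3 this assay reports only a limit, > 10000 nM, not a number (the limit of > 10000 nM in this assay, at which 1 of the 3 values shown sits).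

Compound 4 `COc1ccc2[nH]c(C(=O)N3CC(=O)N(Cc4ccccc4)[C@@H](CN4CCC5(CCCC5)CC4)C3)cc2c1` is not yet measured. It differs from compound 1 as follows: a group of 10 heavy atoms (9 carbon, 1 nitrogen; one five-membered non-aromatic ring of carbon only, one six-membered non-aromatic ring with 1 hetero atom) in place of a group of 8 heavy atoms (7 carbon, 1 nitrogen; one three-membered non-aromatic ring of carbon only, one six-membered non-aromatic ring with 1 hetero atom), on a saturated chain carbon bound to a saturated ring carbon. Within the data shown here, no measured pair differs in this one place alone, so the size of the step is unknown; a modest decrease or no change beyond the scatter is expected, since compound 2 with its four-membered variant gave 7800 nM alongside a differing aromatic substituent. The expected step from compound 1 to compound 4 is a 1.7-fold lower number from compound 1 to compound 4 (0.23 log units; within the scatter). Compound 4 is expected to give 10000 nM in this assay, between 4000 nM and 25000 nM.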

Compound 4, half-maximal cytotoxic concentration: 3600 nM
Estimate against measurement, compound 4: 2.8-fold (0.44 log units) above; measured number outside the range, below it.
By their numbers in this assay, from the lowest: compound 4; then compound 2; then compound 1.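

Among these compounds, this is the first direct reading at this place. In this assay, with the rest of compound 1 unchanged, the group with the five-membered carbon ring in place of the group with the three-membered carbon ring gives a 4.8-fold lower number from compound 1 to compound 4 (0.68 log units; beyond the scatter), so the enlarged group carries a real cost in tolerated compound although hydrogen-bond counts and charge stay the same. Nothing measured here bears on the reason for this step.

Still open, going by these compounds, is whether a morpholine or piperazine at this place would restore the number of compound 1. Also open, on these data alone, is whether the step holds on the core of compound 2.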